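Moving the Chlorine Around the Phenyl Ring

The compounds below may be only part of what the source reports. "The series", "measured", "known", "first", "only" and "open" are said of these compounds alone.

Measured in a functional assay on PANC-1 cells (Homo sapiens) for inhibition, read by MTT assay, with a stated time of 24 h; on this read-out lower numbers stand for stronger inhibition and higher numbers for weaker inhibition:
Compound 1 `CC1(C)[C@H]2CC[C@]1(C)N(Cc1cn(-c3ccc(C#N)cc3)nn1)C(=O)C2` gives 250 nM
Compound 2 `CC1(C)[C@H]2CC[C@]1(C)N(Cc1cn(-c3ccccc3C#N)nn1)C(=O)C2` gives 240 nM
Compound 3 `CC1(C)[C@H]2CC[C@]1(C)N(Cc1cn(-c3ccccc3Cl)nn1)C(=O)C2` gives 270 nM

Compound 3 stands level with compound 1 and compound 2, as every step among the three lies within the usual scatter. Compound 4 `CC1(C)[C@H]2CC[C@]1(C)N(Cc1cn(-c3cccc(Cl)c3)nn1)C(=O)C2` has 3-chlorophenyl in place of 2-chlorophenyl on an aromatic nitrogen. Among the measured compounds shown here, the closest precedent moves a nitrile around the same phenyl ring, giving a 1.0-fold lower number from compound 1 to compound 2 (0.02 log units; within the scatter). Exchanging the group itself gave a 1.1-fold higher number from compound 2 to compound 3 (0.05 log units; within the scatter), and the remaining pair gave a 1.1-fold higher number from compound 1 to compound 3 (0.03 log units; within the scatter). For the measured compounds named here, none of the measured compounds carries 3-chlorophenyl, so this expectation rests on little. No step beyond the scatter is expected in this assay, and the estimate means a 1.0-fold lower number from compound 3 to compound 4 (0.02 log units; within the scatter). The estimated value for compound 4 is 260 nM, with an expected range from 130 nM to 500 nM.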

Compound 4, half-maximal inhibitory concentration: 260 nM
Beside the measured number, compound 4's estimate shows no gap at the digits printed, and the stated range covers the measured number.
By their numbers in this assay, from the lowest: compounds 2, 1, 4 and 3 (each within the scatter of the next).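

Moving the chlorine from 2-chlorophenyl to 3-chlorophenyl gives in this assay (a 1.0-fold lower number from compound 3 to compound 4 (0.02 log units; within the scatter)), so chlorine, like the nitrile before it, shows no response to a shift around this ring. Compared with the two nitrile compounds, 3-chlorophenyl also stays level (a 1.1-fold higher number from compound 2 to compound 4 (0.03 log units; within the scatter); a 1.0-fold higher number from compound 1 to compound 4 (0.02 log units; within the scatter)). No independent evidence explains this flat picture.

The compounds shown carry only chloro or nitrile on the phenyl ring. On these data alone, whether an amine or a carboxylic acid there would produce a step beyond the scatter remains open.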